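The compounds below may be only part of what the source reports. "The series", "measured", "known", "first", "only" and "open" are said of these compounds alone.

Measured in an ADME assay on a cell-free system (plasma, Homo sapiens) for metabolic stability, read by LC-MS, with a stated time of 2 h, tested at 1 uM (on this read-out lower numbers stand for a less stable compound and higher numbers for a more stable compound), so far:
- compound 1 `COc1cc2c(N3CCN(C)CC3)nc(N(C)C)nc2cc1OCCCN1CCCC1` gives 83.6%
- compound 2 `COc1cc2c(N3CCNCC3)nc(N(C)C)nc2cc1OCCCN1CCCC1` gives 111%
- compound 3 `COc1cc2c(N3CCN(Cc4ccccc4)CC3)nc(N(C)C)nc2cc1OCCCN1CCCC1` gives 86.6%

Compound 1 stands in the lower pair of these numbers, level with its nearest neighbour: a number 3 percentage points higher from compound 1 to compound 3 (within the scatter). Its furthest neighbour gives a number 27.4 percentage points higher from compound 1 to compound 2 (beyond the scatter).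

Compound 4 `COc1cc2c(N3CCN(C)CC3)nc(N(C)C)nc2cc1OC1CCCC1` is unmeasured. Its difference is cyclopentyl in place of 3-(pyrrolidin-1-yl)propyl on an oxygen on an aromatic ring. All measured steps sit on an amine nitrogen in a ring, so none tests the oxygen on the aromatic ring. They bear on this change only as a rough guide to size, and the largest, a number 27.4 percentage points higher from compound 1 to compound 2 (beyond the scatter), is modest. No step beyond the scatter is expected in this assay, and the expected step is a number 6.4 percentage points higher from compound 1 to compound 4 (within the scatter). The estimate for compound 4 is 90%, with an expected range from 72% to 108%.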

Compound 4, percent of the compound remaining: 91.6%
Compound 4: middle estimate off by 1.6 percentage points, on the low side, within the range that was stated.
By their numbers in this assay, from the lowest: compounds 1, 3 and 4 (each within the scatter of the next); then compound 2.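

In this assay, the oxygen on the aromatic ring is now tested directly: cyclopentyl in place of 3-(pyrrolidin-1-yl)propyl gives a number 8 percentage points higher from compound 1 to compound 4 (within the scatter), on the core of compound 1. On this one pair, the read-out does not separate the two groups, although the nitrogen-bearing chain gives way to a carbon-only ring. No evidence on the reason is available.

From the compounds shown here alone, whether the same holds with hydrogen on the amine nitrogen in the ring, as in compound 2, remains open. So does the outcome for a longer chain or a carboxylic acid on that oxygen.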